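The source may hold more compounds than are shown below. What is called first, only, known or untested is meant among the compounds shown, and "the series" means these compounds.

Measured compounds:
compound 1, `Cc1cc(NC(=O)Cn2nnc(-c3ccccc3)n2)n(C2CCCCC2)n1`, giving 92% in an assay on HEK293 cells for activation of Kir3.1/Kir3.2 (Homo sapiens), read by thallium flux; a higher number here means a larger maximal response, a lower number a smaller maximal response.
compound 2, `CC1(c2cc(NC(=O)Cn3nnc(-c4ccccc4)n3)n(C3CCCCC3)n2)CC1`, giving only a limit of > 10% in this assay.

Compound 1 holds the only readable number shown; the other value shown is a limit. Compound 2 gives > 10%, and this is a limit of the assay, not a number (the limit of > 10% in this assay, at which 1 of the 2 values shown sits). The measured step that the limit leaves unreadable from compound 1 to compound 2 changes a group on another aromatic carbon and is therefore left unreadable.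

Compound 3, `Cc1cc(NC(=O)Cn2nnc(C3CC3)n2)n(C2CCCCC2)n1`, is not yet measured. It differs from compound 1 by cyclopropyl in place of phenyl on an aromatic carbon. Among the compounds with values here, no measured step touches this place, and the one measured step is unreadable, so nothing measured bears on the size or direction of the change in this assay. Compound 3 is therefore expected to lie at 70%, within 30% to 100%. The expected step is a number 22 percentage points lower from compound 1 to compound 3 (beyond the scatter).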

Compound 3, largest response reached (Emax), in percent of the reference or control that the assay uses: > 68%
Compound 3: only a limit was reported; the forecaster's own chance of this, stated with the estimate: 20%; the middle value lies beyond the limit too.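

In this assay, within the data shown here, compound 3 gives > 68% as a limit, not a number, so no step from compound 1 to compound 3 can be read. The compounds shown leave open how large the maximal responses of compound 2 and compound 3 are, and so what either replacement does to the response.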